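A few compounds are considered here, and "the series" means these few. Any claim that something is new, unique, unknown or untested is made for them only; others in the source may bear on it.

Compound 1 `COc1cc(OC)c(OC)cc1/C=C/C(=O)c1ccc(C)cc1`, compound 2 `COc1cc(OC)c(OC)cc1/C=C/C(=O)c1cc(OC(C)=O)ccc1OC(C)=O` and compound 3 `COc1cc(OC)c(OC)cc1/C=C/C(=O)c1cc(Cl)ccc1O` share one core and differ only in the ring on the carbonyl carbon. In a functional assay on SW982 cells (Homo sapiens) for inhibition, read by MTT assay, with a stated time of 72 h (on this read-out higher numbers stand for weaker inhibition and lower numbers for stronger inhibition), compound 1 gives 81100 nM. Compound 2 gives 78500 nM in this assay, a value within the scatter of compound 1. Compound 3 reaches only a limit in this assay, > 150000 nM, and no number is known for it (the limit of > 150000 nM in this assay, at which 1 of the 3 values shown sits). Going by the values given here, the one single-change step, an at least 1.8-fold higher number from compound 1 to compound 3 (0.26 log units; that floor lies within the scatter), runs from a number up to that limit, and its true size is unknown.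

Compound 4 `COc1cc(OC)c(OC)cc1/C=C/C(=O)c1ccc(O)cc1` differs from compound 3 by 4-hydroxyphenyl in place of 5-chloro-2-hydroxyphenyl on a carbonyl carbon. Among the compounds with values here, no measured step involves a 4-hydroxyphenyl group, so the expectation rests on the range the series occupies: the two measured numbers and one limit. Compound 4 is expected to return to that measured range, a step of an at least 1.5-fold lower number from compound 3 to compound 4 (0.19 log units; that floor lies within the scatter) in this assay, with a real chance of another limit. The estimate for compound 4 is 95000 nM, between 40000 nM and 220000 nM.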

Compound 4, half-maximal inhibitory concentration: 155000 nM
Compound 4: middle estimate off by 1.6-fold (0.21 log units), on the low side, within the range that was stated.
By their numbers in this assay, from the lowest: compounds 2, 1 and 4 (each within the scatter of the next).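

Hydroxy in place of methyl on an aromatic carbon gives a 1.9-fold higher number from compound 1 to compound 4 (0.28 log units; within the scatter) in this assay, so at this position the change does not separate the two compounds. Compound 3 stands only at a limit, so its step to compound 4 cannot be read: the limit of > 150000 nM in this assay, at which 1 of the 4 values shown sits.
Compounds 2, 1 and 4 each lie within the scatter of the next, so none of the three rings with a measured number on the carbonyl carbon sets its compound apart from its neighbour in that order.

The compounds shown leave open whether an amine or a carboxylic acid on that aromatic carbon would give a step beyond the scatter. On these data alone, how far compound 3 truly lies from the others also remains unknown.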